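The source may report more compounds than this note shows. Statements on the series, on what has been measured and on what is new or still open speak of the compounds shown alone.

Compound 1 `Cc1c(Cc2ccc(C(F)(F)F)cc2)c(=O)oc2cc(OCC(O)CN3CCC(C(N)=O)CC3)ccc12`: 89300 nM
Compound 2 `Cc1c(Cc2ccc(OC(F)(F)F)cc2)c(=O)oc2cc(OCC(O)CN3CCC(C(N)=O)CC3)ccc12`: 68200 nM
Compound 3 `Cc1c(Cc2ccc(-c3ccc(C#N)c(F)c3)cc2)c(=O)oc2cc(OCC(O)CN3CCC(C(N)=O)CC3)ccc12`: 29100 nM

These values come from an ADME assay on A549 cells (Homo sapiens) for cytotoxicity, read by CellTiter-Glo; on this read-out lower numbers stand for higher toxicity in this test and higher numbers for lower toxicity in this test. Compound 2 sits in the upper part of this small set: a 1.3-fold lower number from compound 1 to compound 2 (0.12 log units; within the scatter), whereas a 2.3-fold lower number from compound 2 to compound 3 (0.37 log units; beyond the scatter). The next compound to be tested is compound 4 `Cc1c(Cc2ccc(OC(F)(F)F)cc2)c(=O)oc2cc(OCC(O)CNc3nccs3)ccc12`. Its change from compound 2 is (1,3-thiazol-2-yl)amino in place of 4-carbamoylpiperidin-1-yl on a saturated chain carbon, two bonds along the chain from an oxygen on a saturated carbon. In words, (1,3-thiazol-2-yl)amino stands in place of 4-carbamoylpiperidin-1-yl on a saturated chain carbon, two bonds along the chain from an oxygen on a saturated carbon.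

Within the data shown here, none of the measured steps changes that group. All three swap a group on an aromatic carbon instead, and the largest is a 3.1-fold lower number from compound 1 to compound 3 (0.49 log units; beyond the scatter). They therefore offer only a rough idea of how far one change can move the number in this set, and no direct evidence on this swap. Still, compound 2 at 68200 nM already lies high among the three, so a lower number seems the likelier direction. The expected step is a 2.3-fold lower number from compound 2 to compound 4 (0.36 log units; beyond the scatter), a modest estimate with wide uncertainty. For compound 4 the estimated value is 30000 nM, within an expected range of 11000 nM to 80000 nM.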

Compound 4, half-maximal cytotoxic concentration: 99000 nM
Beside the measured number, compound 4's estimate is 3.3-fold (0.52 log units) below it; the measured number lies above the stated range.
By their numbers in this assay, from the lowest: compound 3; then compounds 2, 1 and 4 (each within the scatter of the next).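

Among these compounds, compounds 1, 2 and 3 differ only in a group on an aromatic carbon, whereas compound 4 is the first here to change the other end of the molecule, on a saturated chain carbon, two bonds along the chain from an oxygen on a saturated carbon. In this assay the swap of 4-carbamoylpiperidin-1-yl for (1,3-thiazol-2-yl)amino gives a 1.5-fold higher number from compound 2 to compound 4 (0.16 log units; within the scatter) and so stays within the scatter, even though a six-membered non-aromatic ring leaves and a five-membered aromatic ring containing sulfur enters, which means that this one pair shows no measurable shift in this test from a large change of group at this position. No measurement available here explains this result.

A single pair cannot show whether other groups at this position would behave the same way, such as a morpholine ring, a simple dimethylamino group, or a carboxylic acid in place of the carbamoyl on the piperidine. As far as these compounds go, it also remains open whether (1,3-thiazol-2-yl)amino would give a similar result alongside the trifluoromethyl group or the 4-cyano-3-fluorophenyl group instead of trifluoromethoxy.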